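A few compounds are considered here, and "the series" means these few. Any claim that something is new, unique, unknown or untested is made for them only; others in the source may bear on it.

Measured so far:
compound 1 `COC[C@H](NC(=O)[C@H](CSC)NC(=O)c1cc(C)on1)C(=O)N[C@@H](CC(C)C)C(=O)[C@@]1(C)CO1`: 0.195 h
compound 2 `COC[C@H](NC(=O)c1cc(C)on1)C(=O)NCC(=O)N[C@@H](CC(C)C)C(=O)[C@@]1(C)CO1`: 2.06 h

In an ADME assay on microsomes from liver (Mus musculus) for metabolic stability (a higher number here means that the compound lasts longer, a lower number that the compound disappears faster), compound 1 gives 0.195 h, while compound 2 stands higher of the two at 2.06 h, a gap beyond the scatter. Compound 3 `CSC[C@H](NC(=O)c1cc(C)on1)C(=O)NCC(=O)N[C@@H](CC(C)C)C(=O)[C@@]1(C)CO1` differs from compound 2 by methylsulfanyl in place of methoxy on a saturated chain carbon, two bonds along the chain from an amide-type nitrogen and a carbonyl carbon: methylsulfanyl in place of methoxy on a saturated chain carbon. For the measured compounds named here, no single-place step has been measured. Differing from compound 2 elsewhere too, compound 1, which also carries methylsulfanyl, gives 0.195 h, so a fall beyond the scatter is expected, with an estimated 2.6-fold lower number from compound 2 to compound 3 (0.41 log units; beyond the scatter). For compound 3 the estimate is 0.8 h, with an expected range of 0.25 h to 2 h.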

Compound 3, half-life: 0.705 h
For compound 3 the middle estimate is 1.1-fold (0.05 log units) above the measured one, and the stated range covers the measured number.
By their numbers in this assay, from the lowest: compound 1; then compound 3; then compound 2.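

In this assay, methylsulfanyl in place of methoxy on a saturated chain carbon now has its own single-place reading, with a 2.9-fold lower number from compound 2 to compound 3 (0.47 log units; beyond the scatter) and no other change involved. Hydrogen in place of methoxymethyl gives a 3.6-fold higher number from compound 1 to compound 3 (0.56 log units; beyond the scatter) with methylsulfanyl kept, so a second place also moves the half-life. Nothing available explains either step. Open, as far as these compounds go, is whether ethoxy or a dimethylamino group at the methoxy position would stay closer to compound 2. Also open, from the compounds shown here alone, is whether the methoxymethyl step holds with methoxy in place of methylsulfanyl.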